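Removing one fluoro from a short-lived compound

A few compounds are considered here, and "the series" means these few. Any claim that something is new, unique, unknown or untested is made for them only; others in the source may bear on it.

compound 1 `O=C(NNS(=O)(=O)c1ccccc1F)c1cc(F)cc(-n2cccn2)c1`: 0.0833 h
compound 2 `O=C(NNS(=O)(=O)c1ccccc1F)c1cc(F)cc(-c2ccccn2)c1`: 0.217 h

In an ADME assay on microsomes from liver (Mus musculus) for metabolic stability, read by HPLC, using NADPH, with a stated time of 60 min, tested at 1 uM, in the presence of a further agent that is not named here (on this read-out higher numbers stand for a longer-lived compound and lower numbers for a shorter-lived compound), compound 1 gives 0.0833 h, the lower of the two numbers. Compound 3 `O=C(NNS(=O)(=O)c1ccccc1F)c1cccc(-n2cccn2)c1` differs from it by hydrogen in place of fluoro on an aromatic carbon. Among the measured compounds shown here, the only measured step, a 2.6-fold higher number from compound 1 to compound 2 (0.42 log units; beyond the scatter), is a different change: pyridin-2-yl in place of 1H-pyrazol-1-yl. It therefore gives no direct guide to this swap, and no shift beyond the scatter is expected in this assay. The expected step is a 1.0-fold lower number from compound 1 to compound 3 (0.02 log units; within the scatter). For compound 3 the estimate is 0.08 h, with an expected range of 0.04 h to 0.17 h.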

Compound 3, half-life: 0.167 h
For compound 3 the middle estimate is 2.1-fold (0.32 log units) below the measured one; measured number inside the range.
By their numbers in this assay, from the lowest: compounds 1, 3 and 2 (each within the scatter of the next, the first and the last beyond it).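

In this assay, hydrogen in place of fluoro on this aromatic carbon, meta to a 1H-pyrazol-1-yl group, gives a 2.0-fold higher number from compound 1 to compound 3 (0.30 log units; within the scatter) and so does not show that this fluoro matters for the half-life. Nothing measured here offers a reason for this result. Still open, going by these compounds, is whether the same swap would read alike on compound 2, which carries pyridin-2-yl. Also open, on these data alone, is whether a methoxy or an amine on this carbon would move the number beyond the scatter.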